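The compounds below may be only part of what the source reports. "The series", "measured", "known", "first", "only" and "open" are said of these compounds alone.

Series notes. Three compounds of a shared core have been run in a functional assay on KM12 cells (Homo sapiens) for antiproliferative activity; a higher number here means a weaker inhibitor of growth, a lower number a stronger inhibitor of growth. Compound 1 `Oc1ccc(-c2nc3ccccc3s2)cc1O` gives 15600 nM. Compound 2 `Oc1ccc(-c2nc3cc(F)ccc3s2)cc1O` gives 13000 nM. Compound 3 `COc1ccc(-c2nc3cc(F)ccc3s2)cc1O` gives 18400 nM. Compound 2 returns the lowest of the three numbers, but its separation from compound 1 is a 1.2-fold lower number from compound 1 to compound 2 (0.08 log units; within the scatter) and from compound 3 is a 1.4-fold higher number from compound 2 to compound 3 (0.15 log units; within the scatter), both within the scatter, so the three stand level on these data.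

Compound 4 `COc1cc(-c2nc3cc(F)ccc3s2)ccc1O` has not yet been run in this assay. Relative to compound 2 the change is methyl in place of hydrogen on an oxygen on an aromatic ring. Among the compounds with values here, the step that bears most directly on it is the one from compound 2 to compound 3, the same kind of change made on the other oxygen on the aromatic ring, which gave a 1.4-fold higher number from compound 2 to compound 3 (0.15 log units; within the scatter). The step from compound 1 to compound 2, a 1.2-fold lower number from compound 1 to compound 2 (0.08 log units; within the scatter), concerns the fluoro on the aromatic carbon and offers no further guide to this change.

Because the step from compound 2 to compound 3 was a 1.4-fold higher number from compound 2 to compound 3 (0.15 log units; within the scatter), no step beyond the scatter is expected here either, with any drift towards a higher number. The expected step in this assay from compound 2 to compound 4 is a 1.2-fold higher number from compound 2 to compound 4 (0.09 log units; within the scatter). Compound 4 is therefore estimated at 16000 nM, with a range of 8000 nM to 32000 nM.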

Compound 4, concentration for 50% growth inhibition: 47300 nM
Compound 4: middle estimate off by 3.0-fold (0.47 log units), on the low side, outside the stated range (above it).
By their numbers in this assay, from the lowest: compounds 2, 1 and 3 (each within the scatter of the next); then compound 4.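

In this assay, the change from hydroxy to methoxy at this oxygen gives a 3.6-fold higher number from compound 2 to compound 4 (0.56 log units; beyond the scatter), a modest step but the first in the series to lie beyond the scatter. The same change on the other oxygen on the aromatic ring gives a 1.4-fold higher number from compound 2 to compound 3 (0.15 log units; within the scatter), which stays within the scatter, so in these two steps the two oxygens do not respond alike to methyl in place of hydrogen, and compound 3 stands against any reading that methylation of either oxygen raises the number. The data shown offer no measurement that explains this difference between the two oxygens.

Going by these compounds, it remains open whether the higher number at this position follows from the loss of the hydroxy hydrogen or from the presence of the methyl, a question that an amine or a fluoro in place of the hydroxy could help to separate. Also open, on these data alone, are how a longer chain, such as ethoxy, would read at this oxygen, and whether methoxy on both oxygens would read like compound 4, like compound 3 or differently from both.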